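Pyridin-2-yl Hydrazone Variant on a Shared Core

The compounds below may be only part of what the source reports. "The series", "measured", "known", "first", "only" and "open" are said of these compounds alone.

Compound 2 `Cc1nn(-c2ccccc2)cc1/C=N/Nc1nc(Nc2ccccc2)nc(Nc2ccc(S(N)(=O)=O)cc2)n1` carries a 3-methyl-1-phenyl-1H-pyrazol-4-yl group on a carbon with a double bond to nitrogen. In a functional assay on U-251 cells (Homo sapiens) for inhibition, read by sulforhodamine B assay, with a stated time of 48 h (a higher number here means that more compound is tolerated, a lower number that less compound is tolerated), compound 2 reaches only a limit of the assay, > 100000 nM, so no number is known for it. Its measured neighbour, compound 1 `NS(=O)(=O)c1ccc(Nc2nc(N/N=C/c3ccc(C(F)(F)F)cc3)nc(Nc3ccccc3)n2)cc1`, carries 4-(trifluoromethyl)phenyl at the same carbon, and in this assay compound 1 gives 71400 nM. Among the compounds with values here, the step of an at least 1.4-fold higher number from compound 1 to compound 2 (0.14 log units; that floor lies within the scatter) is the only measured comparison in this set, and its floor stays within the scatter, a floor set by the limit of > 100000 nM in this assay, at which 1 of the 2 values shown sits. Compound 3 `NS(=O)(=O)c1ccc(Nc2nc(N/N=C/c3ccccn3)nc(Nc3ccccc3)n2)cc1` is now considered; it differs from compound 2 in one place: pyridin-2-yl in place of 3-methyl-1-phenyl-1H-pyrazol-4-yl on a carbon with a double bond to nitrogen. Within the data shown here, no measured step bears directly on this exchange; the sole step available, an at least 1.4-fold higher number from compound 1 to compound 2 (0.14 log units; that floor lies within the scatter), swapped a different group at the same carbon and stayed within the scatter. For compound 3 the change an at least 1.1-fold lower number from compound 2 to compound 3 (0.04 log units; that floor lies within the scatter) is therefore expected to remain within the scatter. Compound 3 is estimated at 90000 nM in this assay, within 35000 nM to 250000 nM, with a fair chance that only a limit is reported.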

Compound 3, concentration lethal to 50% of the cells: > 100000 nM
Compound 3 gave a limit, no number; the forecaster's own chance of this, stated with the estimate: 50%; middle value at least 1.1-fold (0.04 log units) away from the limit.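

In this assay compound 3 gives > 100000 nM, a limit of the assay and not a number, so pyridin-2-yl joins 3-methyl-1-phenyl-1H-pyrazol-4-yl as a second group at this carbon that ends at the limit. Exchanging 4-(trifluoromethyl)phenyl for pyridin-2-yl gives an at least 1.4-fold higher number from compound 1 to compound 3 (0.14 log units; that floor lies within the scatter), so this second replacement again shows no difference beyond the scatter, although the true size of the step may be larger. The step between compound 2 and compound 3 cannot be read, and the two groups, though very different in size, cannot be placed in any order, because the limit now caps most of what this series can show: the limit of > 100000 nM in this assay, at which 2 of the 3 values shown sit.

Within the data shown here, it remains open whether compound 1, the only compound with a number, truly differs from compound 2 and compound 3 in this assay, since all that separates them is a floor within the scatter. Going by these compounds, it also remains open whether a phenyl ring carrying an amine or a carboxylic acid at this carbon, or a simple alkyl chain there, would give a number rather than a limit.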